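A few compounds are considered here, and "the series" means these few. Any claim that something is new, unique, unknown or untested is made for them only; others in the source may bear on it.

Among the measured compounds shown here, only two compounds have numbers so far: in an ADME assay on L02 cells (Homo sapiens) for cytotoxicity, read by MTT assay, with a stated time of 24 h (on this read-out lower numbers stand for stronger inhibition and higher numbers for weaker inhibition), compound 1 `CN1C/C(=C\c2cccnc2)C(=O)/C(=C/c2ccccc2C(F)(F)F)C1` gives 14100 nM and compound 2 `O=C1/C(=C/c2cccnc2)CN(S(=O)(=O)c2ccccc2)C/C1=C\c1ccccc1F` gives 15300 nM and thus stands level with compound 1 within the usual scatter of repeated measurements. Compound 3 `O=C1/C(=C/c2cccnc2)CN(S(=O)(=O)c2ccccc2)C/C1=C\c1ccccc1C(F)(F)F` is still unmeasured and differs from compound 2 in one place (trifluoromethyl in place of fluoro on an aromatic carbon): trifluoromethyl in place of fluoro on an aromatic carbon, ortho to a large group. For the measured compounds named here, no measured pair shows this exchange on its own, so the evidence is thin. Compound 1 carries a 2-(trifluoromethyl)phenyl and gives 14100 nM in this assay with no gap to compound 2 beyond the scatter, so no shift beyond the scatter is expected in either direction. The estimated step of a 1.1-fold lower number from compound 2 to compound 3 (0.04 log units; within the scatter) is accordingly small. Compound 3 is expected at 14000 nM with an estimated range from 6500 nM to 30000 nM as the likely span.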

Compound 3, half-maximal inhibitory concentration: 12500 nM
Estimate against measurement, compound 3: 1.1-fold (0.05 log units) above, within the range that was stated.
By their numbers in this assay, from the lowest: compounds 3, 1 and 2 (each within the scatter of the next).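

Among the compounds shown here, compound 3 gives the first direct look at this exchange: in this assay, going from 2-fluorophenyl to 2-(trifluoromethyl)phenyl gives a 1.2-fold lower number from compound 2 to compound 3 (0.09 log units; within the scatter), so a group of 4 heavy atoms and a single fluoro at this aromatic carbon cannot be told apart here. It also links the two different substituents on the ring amine nitrogen, where phenylsulfonyl in place of methyl gives a 1.1-fold lower number from compound 1 to compound 3 (0.05 log units; within the scatter), and these two compounds likewise cannot be told apart. No measured property is available to explain either result.

The compounds shown leave open whether a methoxy group, an amine or a carboxylic acid on that aromatic carbon would shift the number beyond the scatter. They also leave open whether an acetyl group or a longer alkyl chain on the ring nitrogen would do so.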